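The source may hold more compounds than are shown below. What is called first, only, known or untested is meant among the compounds shown, and "the series" means these compounds.

Working notes on the series. Going by the values given here, compound 3 `COc1cc(-c2cc(/C=C/C(=O)c3ccc(C)c(C)c3)nc3cc(-c4ccccc4)nn23)cc(OC)c1OC` gives, in a functional assay on MDA-MB-231 cells (Homo sapiens) for antiproliferative activity, read by MTT assay, with a stated time of 24 h (a lower number here means a stronger inhibitor, a higher number a weaker inhibitor), a value of 13500 nM, the lowest of the three numbers so far; compound 2 `COc1ccc(/C=C/C(=O)c2cc(-c3cc(OC)c(OC)c(OC)c3)n3nc(-c4ccccc4)cc3n2)cc1OC` gives 14200 nM and compound 1 `COc1cc(-c2cc(C(=O)/C=C/c3ccc(Cl)cc3)nc3cc(-c4ccccc4)nn23)cc(OC)c1OC` gives 21600 nM, both within the scatter of compound 3, so no ordering is claimed. Compound 4 `COc1cc(-c2cc(C(=O)/C=C/c3ccc(C)cc3)nc3cc(-c4ccccc4)nn23)cc(OC)c1OC` differs from compound 3 by (2-(4-methylphenyl)ethenyl)carbonyl in place of 2-((3,4-dimethylphenyl)carbonyl)ethenyl on an aromatic carbon. The two measured steps, a 1.5-fold lower number from compound 1 to compound 2 (0.18 log units; within the scatter) and a 1.6-fold lower number from compound 1 to compound 3 (0.20 log units; within the scatter), change the same chain and its aryl group without moving the number beyond the scatter, so no step beyond the scatter is expected in this assay either; the expected step is a 1.1-fold higher number from compound 3 to compound 4 (0.05 log units; within the scatter). Compound 4 is therefore estimated at 15000 nM in this assay, with a range of 7000 nM to 32000 nM.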

Compound 4, half-maximal inhibitory concentration: 18600 nM
The estimate for compound 4 lay 1.2-fold (0.09 log units) below the measured number, and the stated range covers the measured number.
By their numbers in this assay, from the lowest: compounds 3, 2, 4 and 1 (each within the scatter of the next).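

In this assay, (2-(4-methylphenyl)ethenyl)carbonyl in place of 2-((3,4-dimethylphenyl)carbonyl)ethenyl on the aromatic carbon next to the ring nitrogen gives a 1.4-fold higher number from compound 3 to compound 4 (0.14 log units; within the scatter), so this exchange stays within the scatter. On the aryl end of the chain, methyl in place of chloro gives a 1.2-fold lower number from compound 1 to compound 4 (0.06 log units; within the scatter), and 4-methylphenyl in place of 3,4-dimethoxyphenyl gives a 1.3-fold higher number from compound 2 to compound 4 (0.12 log units; within the scatter), so a small methyl-bearing aryl group also leaves the number within the scatter. No measurement at hand accounts for these numbers. On these data alone, whether an amine or a carboxylic acid on that aryl ring would move the number beyond the scatter stays open.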